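The source may report more compounds than this note shows. Statements on the series, on what has been measured and on what is new or still open speak of the compounds shown alone.

In a functional assay on LOX IMVI cells (Homo sapiens) for cytotoxicity (a higher number here means a weaker inhibitor of growth, a lower number a stronger inhibitor of growth), compound 2 (`OCCCCC#Cc1ccccc1C#Cc1ccc(O)cc1`) gives 13600 nM and compound 1 (`OCCCCC#Cc1ccccc1C#Cc1cccs1`) gives 13900 nM, so the two stand level within the scatter. Among the measured compounds shown here, the only measured step, a 1.0-fold lower number from compound 1 to compound 2 (0.01 log units; within the scatter), lies within the scatter and concerns the group on a triple-bonded carbon, not the hydroxy. Compound 3 (`OCCCCC#Cc1ccccc1C#Cc1ccc(C(F)(F)F)cc1`) carries trifluoromethyl in place of hydroxy on an aromatic carbon, para to a large group: trifluoromethyl in place of hydroxy on an aromatic carbon. For the measured compounds named here, no measured step tests this exchange, so no shift beyond the scatter is expected in this assay. The expected step is a 1.1-fold lower number from compound 2 to compound 3 (0.05 log units; within the scatter). Compound 3 is estimated at 12000 nM, within 5000 nM to 28000 nM.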

Compound 3, concentration for 50% growth inhibition: 17100 nM
Compound 3: the middle estimate sits 1.4-fold (0.15 log units) below what was measured; measured number inside the range.
By their numbers in this assay, from the lowest: compounds 2, 1 and 3 (each within the scatter of the next).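

At this position, on an aromatic carbon para to a large group, trifluoromethyl in place of hydroxy gives a 1.3-fold higher number from compound 2 to compound 3 (0.10 log units; within the scatter) in this assay. The hydroxy, with its hydrogen-bond donor and acceptor, can thus be exchanged for trifluoromethyl, which has neither, without a step beyond the scatter; the earlier step tested only the group on the triple-bonded carbon. No measurement shown bears on the reason for this result. The compounds shown leave open whether an amine or a carboxylic acid at this position would give a step beyond the scatter.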